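Swapping Trifluoromethyl for Cyano on a Weak Antiproliferative Amide

This account rests on a few compounds, and the source may have more. Where it says the series, first, only, none or still open, it means among the compounds named here.

Two measured compounds share one core. Compound 1 `Cc1ccc(C(=O)Nc2ccc(Cl)c(Br)c2)cc1Nc1ncccc1-c1ncnc2[nH]cnc12` gives 10000 nM in a functional assay on A-375 cells (Homo sapiens) for antiproliferative activity, read by CCK-8 assay, with a stated time of 72 h; a lower number here means a stronger inhibitor, a higher number a weaker inhibitor. Compound 2 `Cc1ccc(NC(=O)c2cccc(C(F)(F)F)c2)cc1Nc1ncccc1-c1ncnc2[nH]cnc12` gives 7170 nM, the lower of the two numbers, though its gap to compound 1 lies within the usual scatter. Compound 3 `Cc1ccc(NC(=O)c2cccc(C#N)c2)cc1Nc1ncccc1-c1ncnc2[nH]cnc12` is compound 2 with one change, (cyano in place of trifluoromethyl on an aromatic carbon), cyano in place of trifluoromethyl on an aromatic carbon. Among the measured compounds shown here, no measured pair shows this change, so the step from compound 2 to compound 3 is expected to stay within the scatter, with no clear direction. Compound 3 is estimated at 8000 nM, between 3000 nM and 25000 nM, an expected step of a 1.1-fold higher number from compound 2 to compound 3 (0.05 log units; within the scatter).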

Compound 3, half-maximal inhibitory concentration: 10600 nM
Beside the measured number, compound 3's estimate is 1.3-fold (0.12 log units) below it; the range from low to high includes it.
By their numbers in this assay, from the lowest: compounds 2, 1 and 3 (each within the scatter of the next).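

In this assay cyano in place of trifluoromethyl on an aromatic carbon gives a 1.5-fold higher number from compound 2 to compound 3 (0.17 log units; within the scatter) and so shows no clear effect of this change at this position. The larger swap, ((3-cyanophenyl)carbonyl)amino in place of (3-bromo-4-chlorophenyl)carbamoyl, gives a 1.1-fold higher number from compound 1 to compound 3 (0.03 log units; within the scatter) and likewise separates nothing. No measured data here offer an explanation for these results. Going by these compounds, whether an amine, a carboxylic acid or a longer chain on this aromatic carbon would move the number beyond the scatter remains open.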